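From Benzyl to 4-Bromophenyl on a Shared Core

A few compounds are considered here, and "the series" means these few. Any claim that something is new, unique, unknown or untested is made for them only; others in the source may bear on it.

Of the compounds shown here, three sharing one core have been measured in a functional assay on MGC-803 cells (Homo sapiens) for inhibition, read by sulforhodamine B assay; a higher number here means a weaker inhibitor, a lower number a stronger inhibitor. Compound 1 `O=C1C=C(NCc2ccccc2)C(=O)c2c1nc1n2[C@H]2OC[C@@H](O)[C@H]2OC1` gives 2670 nM, compound 2 `O=C1C(Nc2ccccc2F)=CC(=O)c2c1nc1n2[C@H]2OC[C@@H](O)[C@H]2OC1` gives 2000 nM and compound 3 `COc1ccccc1NC1=CC(=O)c2c(nc3n2[C@H]2OC[C@@H](O)[C@H]2OC3)C1=O` gives 1670 nM. These three values lie within the scatter of one another, so compound 1 cannot be separated from its two neighbours.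

The next candidate is compound 4 `O=C1C=C(Nc2ccc(Br)cc2)C(=O)c2c1nc1n2[C@H]2OC[C@@H](O)[C@H]2OC1`. It differs from compound 1 by one change: 4-bromophenyl in place of benzyl on an amine nitrogen. In short, 4-bromophenyl takes the place of benzyl on an amine nitrogen. For the measured compounds named here, no measured step covers this swap directly, and no measured compound carries bromine.

Going by the values given here, the only step available is a change on the aromatic ring, a 1.2-fold lower number from compound 2 to compound 3 (0.08 log units; within the scatter), and it stays within the scatter. Indirect support comes from compound 2 at 2000 nM and compound 3 at 1670 nM, which also have a substituted phenyl ring on an amine nitrogen and sit level with compound 1. Nothing here points to a step beyond the scatter in either direction.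

The estimated change is a 1.4-fold lower number from compound 1 to compound 4 (0.15 log units; within the scatter), which would remain within the scatter. For compound 4, the expected value is 1900 nM, with an estimated range from 750 nM to 4800 nM.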

Compound 4, half-maximal inhibitory concentration: 1010 nM
The estimate for compound 4 lay 1.9-fold (0.27 log units) above the measured number; the measured number falls inside the stated range.
By their numbers in this assay, from the lowest: compounds 4, 3, 2 and 1 (each within the scatter of the next, the first and the last beyond it).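

In this assay, for the compounds shown here, putting 4-bromophenyl in place of benzyl on an amine nitrogen gives a 2.6-fold lower number from compound 1 to compound 4 (0.42 log units; beyond the scatter), and this modest step is the first on the shared core to lie beyond the scatter, since the only earlier step, a 1.2-fold lower number from compound 2 to compound 3 (0.08 log units; within the scatter), did not. Going by these compounds alone, it shows that the number can respond to the group at this position, which the earlier compounds, all level with one another, could not show. The two groups have the same heavy-atom count and each carries one six-membered aromatic ring of carbon only, so that count does not separate them, and no measurement shown here accounts for the step.

The swap makes two differences at once, adding the bromine and removing the methylene carbon of benzyl, and these compounds cannot tell which of the two goes with the lower number. A plain phenyl group on the same nitrogen would help to separate the two, while 4-chlorophenyl would ask whether bromine itself is needed or another halogen serves as well.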